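Alkyl ester homologues of an N-oxyphthalimide series

The source may report more compounds than this note shows. Statements on the series, on what has been measured and on what is new or still open speak of the compounds shown alone.

Measured so far in a functional assay on the whole organism for inhibition, with Lepidium sativum as the target, tested at 1 ppm; a higher number here means more inhibition of growth at the concentration tested, a lower number less inhibition of growth:
- compound 1, `COC(=O)C(C)ON1C(=O)c2ccccc2C1=O`: 64%
- compound 2, `CCOC(=O)C(Cc1ccccc1)ON1C(=O)c2ccccc2C1=O`: 0%
- compound 3, `CCCOC(=O)C(C)ON1C(=O)c2ccccc2C1=O`: 64%

Compound 1 stands level with compound 3, within the scatter, and these two sit together at the top of the three numbers; compound 2 lies far below both, beyond the scatter. Compound 2 differs from compound 1 in more than one place, so its number says nothing on its own about the ester chain.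

Compound 4, `CCCCOC(=O)C(C)ON1C(=O)c2ccccc2C1=O`, is not yet measured. It differs from compound 1 by propyl in place of hydrogen on a saturated chain carbon bound to an oxygen next to a carbonyl group.

Within the data shown here, one measured step bears on this change and sits at the same place: no change at the digits printed from compound 1 to compound 3 (within the scatter). Among the measured compounds shown here, the shared core is untouched in both cases, and the only step of this kind showed nothing beyond the scatter. The step to compound 4 is therefore expected to be a number 2 percentage points lower from compound 1 to compound 4 (within the scatter), no direction beyond the scatter. For compound 4 the estimate in this assay is 62%, within 45% to 78%.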

Compound 4, percent growth inhibition at one concentration: 59%
Compound 4: the middle estimate sits 3 percentage points above what was measured; the measured number falls inside the stated range.
By their numbers in this assay, from the lowest: compound 2; then compounds 4, 1 and 3 (each within the scatter of the next).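

In this assay, the longer replacement of methoxycarbonyl by butoxycarbonyl reads as a number 5 percentage points lower from compound 1 to compound 4 (within the scatter), and the single further methyl on the chain reads as a number 5 percentage points lower from compound 3 to compound 4 (within the scatter). The earlier compounds shown here showed only that propyl in place of hydrogen left the number unmoved; butyl at this place now also stays within the scatter, so compounds 1, 3 and 4 form one level across the methyl, propyl and butyl esters, with no trend readable among them. No supporting data bear on why this position takes these chains without a visible effect.

On these data alone, whether that level holds for a longer chain such as octyl, or for a chain ending in an amine or a carboxylic acid, stays open. Compound 2, at 0%, differs from compound 1 in more than one place, and its number cannot yet be tied to any single change.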